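Changing one stereocentre in a two-compound series

A few compounds are considered here, and "the series" means these few. Any claim that something is new, unique, unknown or untested is made for them only; others in the source may bear on it.

- compound 1 `COc1cc([C@@H]2C[C@]2(CO)C(=O)Nc2ccccc2Cl)cc(OC)c1OC`: 4400 nM
- compound 2 `CCOC(=O)[C@]1(C(=O)Nc2ccccc2Cl)C[C@H]1c1cc(OC)c(OC)c(OC)c1`: 13400 nM

Within the data shown here, in a functional assay on A549 cells (Homo sapiens) for cytotoxicity, read by MTT assay, with a stated time of 48 h (on this read-out higher numbers stand for weaker inhibition and lower numbers for stronger inhibition), compound 1 gives 4400 nM, the lower of the two numbers measured so far. Among the measured compounds shown here, the only measured step, a 3.0-fold higher number from compound 1 to compound 2 (0.48 log units; beyond the scatter), puts ethoxycarbonyl in place of hydroxymethyl on a saturated ring carbon.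

Compound 3 `COc1cc([C@@H]2C[C@@]2(CO)C(=O)Nc2ccccc2Cl)cc(OC)c1OC` has not yet been measured. Its difference from compound 1 is the two compounds have the same atoms and bonds and differ only in configuration as drawn: 1 of 2 stereo elements differ; a stereocentre at a saturated ring carbon is drawn S in compound 1 and R in compound 3. Nothing leaves and nothing enters, and the two compounds have the same atoms and bonds.

For the measured compounds named here, no measured pair differs in configuration alone, so the data give no direct guide to the size or direction of this change. The step to compound 2 bears on it only loosely, as a gauge of how far the number moved with a change at a saturated ring carbon. A modest move towards a higher number is expected, since compound 1 already holds the lower value of 4400 nM, although a result within the scatter remains possible. The expected step is a 1.7-fold higher number from compound 1 to compound 3 (0.23 log units; within the scatter). For compound 3 the estimated value is 7500 nM, with an expected range from 2500 nM to 25000 nM.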

Compound 3, half-maximal inhibitory concentration: 11400 nM
Compound 3: the middle estimate sits 1.5-fold (0.18 log units) below what was measured, and the stated range covers the measured number.
By their numbers in this assay, from the lowest: compound 1; then compounds 3 and 2 (each within the scatter of the next).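

In this assay, turning the one stereocentre at the saturated ring carbon from S to R, with hydroxymethyl kept in place, gives a 2.6-fold higher number from compound 1 to compound 3 (0.41 log units; beyond the scatter). This shift can be placed on that stereocentre alone, because nothing else in the structure changes: the fact that compounds 1 and 3 differ only in the configuration as drawn. Among these compounds, until now the only information about this carbon came from a change of group, which gave a 3.0-fold higher number from compound 1 to compound 2 (0.48 log units; beyond the scatter); the new step shows that configuration at this carbon also moves the number beyond the scatter, and that among the hydroxymethyl compounds the S form drawn in compound 1 gives the lower value.

The compounds shown leave open whether the same preference for S holds with ethoxycarbonyl on this carbon, or what inverting the other stereo element would do. They also leave open how a carboxylic acid or an aminomethyl group in place of hydroxymethyl would read in this assay, and whether configuration would matter as much with either group.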